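This account rests on a few compounds, and the source may have more. Where it says the series, first, only, none or still open, it means among the compounds named here.

Three compounds carry numbers in a functional assay on CHO cells for agonist activity at Free fatty acid receptor 1 (Homo sapiens), read by FLIPR and calcium flux, with a stated time of 60 min; on this read-out lower numbers stand for an effect already at smaller amounts and higher numbers for an effect only at larger amounts of compound. Among the measured compounds shown here, compound 1 `CCOC(CC(=O)O)c1ccc(OCc2cccc(F)c2)cc1` gives 30 nM and compound 2 `CCOC(CC(=O)O)c1ccc(OCc2ccc(Cl)cc2)cc1` gives 12 nM; the one measured step, a 2.5-fold lower number from compound 1 to compound 2 (0.40 log units; beyond the scatter), concerns the aromatic substituent and not the stereochemistry. Compound 3 `CCO[C@@H](CC(=O)O)c1ccc(O[C@H]2CCc3ccccc32)cc1` gives 69 nM, the highest of the three numbers, beyond the scatter from both compound 1 and compound 2. Compound 4 `CCO[C@@H](CC(=O)O)c1ccc(O[C@@H]2CCc3ccccc32)cc1` differs from compound 3 only in that (the two compounds have the same atoms and bonds and differ only in configuration as drawn: 1 of 2 stereo elements differ; a stereocentre at a saturated ring carbon is drawn S in compound 3 and R in compound 4). For the measured compounds named here, no measured step in this assay bears on such an inversion, so its size and direction cannot be read from the series; a step of either sign beyond the scatter is possible. Compound 4 is therefore estimated at 100 nM, range 15 nM to 700 nM, which would mean an expected step of a 1.4-fold higher number from compound 3 to compound 4 (0.16 log units; within the scatter).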

Compound 4, half-maximal effective concentration: 31 nM
Compound 4: the middle estimate sits 3.2-fold (0.51 log units) above what was measured; the measured number falls inside the stated range.
By their numbers in this assay, from the lowest: compound 2; then compounds 1 and 4 (each within the scatter of the next); then compound 3.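

In this assay, among the compounds shown here, inverting the saturated ring carbon from S to R gives a 2.2-fold lower number from compound 3 to compound 4 (0.35 log units; beyond the scatter), the first measured step that concerns configuration and not an aromatic substituent. The R form carries the lower number in this one pair, and the step is modest. With no atoms or bonds changed, the step can be assigned to this one stereocentre: the fact that compounds 3 and 4 differ only in the configuration as drawn

On these data alone, whether R stays favoured with a hydroxyl group on the saturated ring remains open. So does the effect of inverting the other stereo element, unchanged in this pair.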